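A few compounds are considered here, and "the series" means these few. Any claim that something is new, unique, unknown or untested is made for them only; others in the source may bear on it.

Of the compounds shown here, three built on one shared core have been tested in a functional assay on UO-31 cells (Homo sapiens) for inhibition, read by sulforhodamine B assay, with a stated time of 48 h; a higher number here means that more compound is tolerated, a lower number that less compound is tolerated. Compound 1 `COc1cc(C)cc(-c2c(-c3ccnc(-c4ccc(C(C)=O)cc4)c3)cnn2CC#N)c1` reaches only the limit of this assay, giving > 100000 nM. Compound 3 `COc1cc(C)cc(-c2nn(CC#N)cc2-c2ccnc(-c3ccc(N(C)C)cc3)c2)c1` also reaches only that limit, giving > 100000 nM. Compound 2 `Cc1cc(O)cc(-c2nn(CC#N)cc2-c2ccnc(-c3ccc(Oc4ccccc4)cc3)c2)c1` gives a number in this assay, 31700 nM. Compound 1 thus stands at the limit of > 100000 nM in this assay, at which 2 of the 3 values shown sit, which is where two of the three values rest, and not at a measured number.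

Compound 4 `COc1cc(C)cc(-c2c(-c3ccnc(-c4ccc(N(C)C)cc4)c3)cnn2CC#N)c1` has not yet been measured. It differs from compound 1 in one place: dimethylamino in place of acetyl on an aromatic carbon. Going by the values given here, no pair of measured compounds separated by a single change is available here, so the size of this step cannot be read from measured data. Compound 3, which carries the same dimethylamino group, sits at the limit of this assay, and compound 1 starts there too. The step from compound 1 to compound 4 is therefore expected to be no larger than the scatter, a number no higher from compound 1 to compound 4 (the limit leaves the size open). Compound 4 is estimated at 100000 nM, expected to lie between 40000 nM and 300000 nM, most likely reported again only as a limit.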

Compound 4, concentration lethal to 50% of the cells: > 100000 nM
Compound 4: no number, only a limit; the forecaster's own chance of this, stated with the estimate: 75%; the middle value sits exactly at the limit.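

Going by these compounds alone, compound 1 and compound 4 both give only a limit in this assay and not a number, so no step between them can be read. As far as these compounds go, what remains open is whether replacing 4-acetylphenyl with 4-(dimethylamino)phenyl changes the lethal concentration at all, since neither compound has a number to compare.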